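Moving from pyridin-4-yl to pyridin-3-yl on compound 2

A few compounds are considered here, and "the series" means these few. Any claim that something is new, unique, unknown or untested is made for them only; others in the source may bear on it.

Compound 1, `Nc1ccccc1NC(=O)c1ccc(CSC(=S)N2CCc3cc(Cl)ccc32)cc1`: 82.2%
Compound 2, `CN(Cc1ccncc1)C(=S)SCc1ccc(C(=O)Nc2ccccc2N)cc1`: 83.2%

In a functional assay on MGC-803 cells (Homo sapiens) for antiproliferative activity, read by CCK-8 assay, with a stated time of 72 h, tested at 8 uM (on this read-out lower numbers stand for a weaker effect and higher numbers for a stronger effect at the one concentration tested), compound 1 gives 82.2% and compound 2 gives 83.2%. Compound 2 holds the higher of the two numbers, with compound 1 nearest, but the step of a number 1 percentage points higher from compound 1 to compound 2 (within the scatter) lies within the scatter, so no order between the two is claimed.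

Compound 3, `CN(Cc1cccnc1)C(=S)SCc1ccc(C(=O)Nc2ccccc2N)cc1`, has not yet been measured. It differs from compound 2 by pyridin-3-yl in place of pyridin-4-yl on a saturated chain carbon bound to an amide-type nitrogen. For the measured compounds named here, no measured step touches this change: the one measured step, a number 1 percentage points higher from compound 1 to compound 2 (within the scatter), exchanged the whole group on the thiocarbonyl carbon and stayed within the scatter. With nothing pointing either way, compound 3 is expected to sit close to compound 2, with a number 3.2 percentage points lower from compound 2 to compound 3 (within the scatter) not reaching beyond the scatter. For compound 3 the estimate in this assay is 80%, with a range from 65% to 92%.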

Compound 3, a percentage reported as inhibition, at one concentration (the size of the read-out at that concentration, not a potency): 85.5%
For compound 3 the middle estimate is 5.5 percentage points below the measured one; the measured number falls inside the stated range.
By their numbers in this assay, from the lowest: compounds 1, 2 and 3 (each within the scatter of the next).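

In this assay, pyridin-3-yl in place of pyridin-4-yl on a saturated chain carbon bound to an amide-type nitrogen gives a number 2.3 percentage points higher from compound 2 to compound 3 (within the scatter) and so lies within the scatter, which means this assay does not tell the two groups apart at this place. The exchange of the whole group on the thiocarbonyl carbon, now with methyl((pyridin-3-yl)methyl)amino in place of 5-chloro-2,3-dihydro-1H-indol-1-yl, gives a number 3.3 percentage points higher from compound 1 to compound 3 (within the scatter) and also separates nothing. No independent measurement is available to explain these results.

On these data alone, whether a pyridin-2-yl group, a plain phenyl ring or a longer chain at this place would stay as close remains open. Which of the three compounds would give a stronger or weaker effect at other concentrations also remains open, as each number reflects the size of the effect at a single concentration.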